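The source may report more compounds than this note shows. Statements on the series, on what has been measured and on what is new or still open speak of the compounds shown alone.

In a functional assay on MCF7 cells (Homo sapiens) for inhibition, read by fluorescence, with a stated time of 72 h (on this read-out higher numbers stand for weaker inhibition and lower numbers for stronger inhibition), three compounds have numbers or limits so far. Compound 1 `Cn1cnc2c(NC(=N)N)nc(N)nc21` returns only a limit of the assay, > 100000 nM. Compound 2 `CCn1cnc2c(N)nc(N)nc21` likewise returns only a limit, > 100000 nM. For the measured compounds named here, compound 3 `CC(C)n1cnc2c(NC(=N)N)nc(NCCCO)nc21` is the single compound of the three with an actual number in this assay, 8800 nM; the other two sit at the limit of > 100000 nM in this assay, at which 2 of the 3 values shown sit, so compound 3 is the only point on which any comparison can rest. Going by the values given here, no step between two measured compounds can be drawn: none of the three differs from another in a single place.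

Compound 4 `CC(C)n1cnc2c(NC(=N)N)nc(OC[C@@H]3CCCN3)nc21` has not yet been measured. It differs from compound 3 in one place, ((pyrrolidin-2-yl)methoxy in place of (3-hydroxypropyl)amino on an aromatic carbon), the exchange falling on an aromatic carbon of a six-membered aromatic ring with 2 nitrogen, part of a fused or bridged system of two rings, between two ring nitrogen atoms.

Among the compounds with values here, with no measured step to show what such an exchange does, the expectation rests on compound 3 alone. Compound 4 is expected to stand apart from compound 3 by a 1.8-fold lower number from compound 3 to compound 4 (0.25 log units; within the scatter), a modest step towards stronger inhibition that may not exceed the usual scatter. Compound 4 is therefore estimated at 5000 nM in this assay, with a range from 1500 nM to 20000 nM.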

Compound 4, half-maximal inhibitory concentration: > 100000 nM
Compound 4: only a limit was reported; the forecaster's own chance of this, stated with the estimate: 10%; middle value at least 20-fold (1.30 log units) away from the limit.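

For the compounds shown here, the exchange of (3-hydroxypropyl)amino for (pyrrolidin-2-yl)methoxy on this aromatic carbon, between two ring nitrogen atoms, gives an at least 11-fold higher number from compound 3 to compound 4 (1.05 log units; beyond the scatter), the first step and one that shows that activity in this assay depends on what this position carries. In this assay compound 4 gives > 100000 nM, which is a limit of the assay and not a number, so the step has a lower bound but no known full size. Going by these compounds alone, compound 3 therefore remains the only compound with an actual number, while the others now share one limit: the limit of > 100000 nM in this assay, at which 3 of the 4 values shown sit.

The exchange alters the linking atom and the rest of the substituent together, so the compounds shown cannot separate the change from amino to oxygen linkage from the change from an open hydroxypropyl chain to a pyrrolidine ring. From the compounds shown here alone, a 3-hydroxypropoxy group or a (pyrrolidin-2-yl)methylamino group on the same carbon would divide these two changes, and the opposite stereocentre of the pyrrolidine and a longer hydroxyalkylamino chain also remain open.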